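The source may report more compounds than this note shows. Statements on the series, on what has been measured and on what is new or still open speak of the compounds shown alone.

Measured in a functional assay on DU-145 cells (Homo sapiens) for antiproliferative activity, read by MTT assay, with a stated time of 3 days; a higher number here means a weaker inhibitor, a lower number a stronger inhibitor:
Compound 1 `CCS(=O)(=O)Nc1ccc(-c2cc(=O)c3c(O)cc(OC)c(OC(C)C)c3o2)cc1`: 17000 nM
Compound 2 `COc1cc(O)c2c(=O)cc(-c3ccc(NS(=O)(=O)C4CC4)cc3)oc2c1OC(C)C`: 48700 nM
Compound 3 `C=CC(=O)Nc1ccc(-c2cc(=O)c3c(O)cc(OC)c(OC(C)C)c3o2)cc1`: 14700 nM

Compound 2 has the highest number of the three in this assay, which makes it the weakest inhibitor here. Compound 4 `COc1cc(O)c2c(=O)cc(-c3ccc(NC(=O)N4CCNCC4)cc3)oc2c1OC(C)C` differs from it in one place, with (piperazin-1-yl)carbonyl in place of cyclopropylsulfonyl on a nitrogen on an aromatic ring. Among the measured compounds shown here, the closest precedent is a 3.3-fold lower number from compound 2 to compound 3 (0.52 log units; beyond the scatter), where vinylcarbonyl enters at that same place. Ethylsulfonyl and vinylcarbonyl differ far less, at a 1.2-fold lower number from compound 1 to compound 3 (0.06 log units; within the scatter), while cyclopropyl in place of ethyl on the sulfonyl sulfur gave a 2.9-fold higher number from compound 1 to compound 2 (0.46 log units; beyond the scatter). Only compound 3 carries a carbonyl on that nitrogen, so the expectation remains loose. A modest drop is expected, a 2.7-fold lower number from compound 2 to compound 4 (0.43 log units; beyond the scatter). For compound 4 the estimated value is 18000 nM, with an expected range from 6000 nM to 50000 nM.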

Compound 4, half-maximal inhibitory concentration: 8000 nM
Beside the measured number, compound 4's estimate is 2.3-fold (0.35 log units) above it; measured number inside the range.
By their numbers in this assay, from the lowest: compounds 4, 3 and 1 (each within the scatter of the next, the first and the last beyond it); then compound 2.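

The (piperazin-1-yl)carbonyl group gives the largest step seen so far on this nitrogen in this assay (a 6.1-fold lower number from compound 2 to compound 4 (0.78 log units; beyond the scatter)), and it also improves on ethylsulfonyl (a 2.1-fold lower number from compound 1 to compound 4 (0.33 log units; beyond the scatter)). Against vinylcarbonyl it shows no separable difference (a 1.8-fold lower number from compound 3 to compound 4 (0.26 log units; within the scatter)), so two quite different groups on the carbonyl carbon are tolerated equally here. No measurement on hand accounts for these differences. 

From the compounds shown here alone, whether the second ring nitrogen of the piperazine matters stays open; a morpholine or a dimethylamine on that carbonyl would separate it from the ring itself. Also open, going by these compounds, is how a longer chain on that carbonyl would read.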